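The source may report more compounds than this note shows. Statements on the series, on what has been measured and on what is new or still open speak of the compounds shown alone.

Of the compounds shown here, three of a shared amide-linked series have been tested in a functional assay on MDA-MB-231 cells (Homo sapiens) for inhibition, read by MTT assay, with a stated time of 48 h; a lower number here means a stronger inhibitor, a higher number a weaker inhibitor. Compound 1, with the structure `COc1cc(/C=C/c2ccc(NC(=O)/C=C/c3ccc(OC)c(OC)c3)cc2)cc(OC)c1`, gives 7740 nM. Compound 2, `COc1cc(/C=C/c2ccc(NC(=O)/C=C/c3cc(OC)c(O)c(OC)c3)cc2)cc(OC)c1`, gives 7130 nM, and compound 3, `COc1cc(/C=C/c2ccc(NC(=O)/C=C/c3cccc(F)c3)cc2)cc(OC)c1`, gives 17300 nM. Among these three numbers compound 1 stands second highest; compound 2 lies closest to it, and the move a 1.1-fold lower number from compound 1 to compound 2 (0.04 log units; within the scatter) stays within the scatter, so no order between them can be claimed. Compound 3 lies furthest away, and the move a 2.2-fold higher number from compound 1 to compound 3 (0.35 log units; beyond the scatter) is a modest but real loss of potency.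

Compound 4, `COc1cc(/C=C/c2ccc(NC(=O)/C=C/c3ccc(F)cc3F)cc2)cc(OC)c1`, has not yet been measured. Its difference from compound 1 is 2,4-difluorophenyl in place of 3,4-dimethoxyphenyl on a double-bonded chain carbon bound to a double-bonded chain carbon. The measured steps that bear on this are the two swaps of a methoxy-bearing ring for a fluorine-bearing ring: a 2.2-fold higher number from compound 1 to compound 3 (0.35 log units; beyond the scatter) and a 2.4-fold higher number from compound 2 to compound 3 (0.38 log units; beyond the scatter), both modest rises in the number. With only these two related steps to lean on, a rise of similar size is the most reasonable expectation for the change to compound 4, though the added second fluorine leaves room for either a smaller or a larger shift.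

Compound 4 is therefore expected to give about 16000 nM in this assay, with a likely range from 8000 nM to 32000 nM, which would amount to the step of a 2.1-fold higher number from compound 1 to compound 4 (0.32 log units; beyond the scatter).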

Compound 4, half-maximal inhibitory concentration: > 20000 nM
Compound 4 gave a limit, no number (the forecaster's own chance of this, stated with the estimate: 5%); at least 1.2-fold (0.09 log units) between middle value and limit.
By their numbers in this assay, from the lowest: compounds 2 and 1 (each within the scatter of the next); then compound 3. At a limit, above all of these: compound 4.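

In this assay compound 4 gives a limit rather than a number: the limit of > 20000 nM in this assay, at which 1 of the 4 values shown sits. The swap of an oxygen-bearing ring for 2,4-difluorophenyl on a double-bonded chain carbon bound to a double-bonded chain carbon gives a rise beyond the scatter in both available comparisons (an at least 2.5-fold higher number from compound 1 to compound 4 (0.41 log units; beyond the scatter); an at least 2.8-fold higher number from compound 2 to compound 4 (0.44 log units; beyond the scatter)), so a second fluorine-bearing ring now joins compound 3 on the weaker side of compound 1 and compound 2, and none of the four compounds goes against this pattern. The second fluorine's own contribution remains unresolved (an at least 1.1-fold higher number from compound 3 to compound 4 (0.06 log units; that floor lies within the scatter)): that floor lies within the scatter, so 2,4-difluorophenyl cannot yet be ranked against 3-fluorophenyl, even though the limit leaves room for a larger gap.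

On these data alone, the true position of compound 4 beyond its limit stays unknown, so the full size of these steps does as well. As far as these compounds go, it also remains open whether an unsubstituted phenyl ring, or a ring carrying an amine or a carboxylic acid, would match compound 1 and compound 2, fall with the fluorine-bearing rings, or surpass them all.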